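The source may report more compounds than this note shows. Statements on the series, on what has been measured and on what is new or still open speak of the compounds shown alone.

Compound 1 `C[C@H](N)C(=O)NCc1cccnc1Oc1ccc(F)cc1F`: 14000 nM in an assay on isolated protein for inhibition of protein arginine N-methyltransferase 6 (Homo sapiens); on this read-out higher numbers stand for weaker inhibition and lower numbers for stronger inhibition.
Compound 2 `C[C@H](N)C(=O)NCc1cccnc1N(C)Cc1ccccc1`: "not active" (no number reported).
Compound 3 `C[C@@H](N)C(=O)NCc1cccnc1Oc1ccc(F)cc1F`: "not active" (no number reported).

All three share the same core, a small amino-acid amide attached to a pyridine bearing an aryl ether or a benzylamine. Within the data shown here, compound 1 is the only one that yields a number in this assay, and that number sits at the weak end. Compound 3 gives no number at all: it is reported as not active, and compound 2 is the other entry without a single value. Among the measured compounds shown here, the only thing that separates compound 1 from compound 3 is the fact that compounds 1 and 3 differ only in the configuration as drawn, so the drawn configuration appears to matter, but with one numbered partner there is no way to put a size on that gap.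

Compound 4 `CNCC(=O)NCc1cccnc1Oc1ccc(F)cc1F` differs from compound 3 by (methylamino)methyl in place of 1-aminoethyl on a carbonyl carbon; the defined stereocentre is lost and the methyl moves from the carbon onto the nitrogen. For the measured compounds named here, no measured pair shows this kind of change, so the direction in this assay cannot be read off the data. Given that both parents sit at or beyond the weak end, compound 4 is expected to be weak as well, with a high chance of returning no number. The estimate for compound 4 in this assay is 30000 nM, in a range from 8000 nM to 150000 nM.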

Compound 4, half-maximal inhibitory concentration: "not active" (no number reported)
Compound 4 has no reported number here, and the estimate cannot be compared.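

Compound 3 and compound 4 are both reported as not active in this assay, with no number for either, so no step can be read between them. The compounds shown leave open whether replacing 1-aminoethyl with (methylamino)methyl changes inhibition at all, and by how much. Nothing at hand explains the result for compound 4.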